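Dichlorophenyl swap on the quinazolinyl ether dienone

The compounds below may be only part of what the source reports. "The series", "measured", "known", "first", "only" and "open" are said of these compounds alone.

Measured compounds: compound 1 `O=C(/C=C/c1ccc(Oc2ncnc3ccc(Cl)cc23)cc1)/C=C/c1c(Cl)cccc1Cl` gives 6770 nM in a functional assay on MGC-803 cells (Homo sapiens) for inhibition, read by MTT assay, with a stated time of 72 h; on this read-out lower numbers stand for stronger inhibition and higher numbers for weaker inhibition; compound 2 `O=C(/C=C/c1cc([N+](=O)[O-])ccc1Cl)/C=C/c1ccccc1Oc1ncnc2ccc(Cl)cc12` gives 1960 nM in this assay; compound 3 `O=C(/C=C/c1ccc(Cl)c(Cl)c1)/C=C/c1ccccc1Oc1ncnc2ccc(Cl)cc12` gives 16200 nM in this assay.

Compound 1 stands second highest of the three numbers in this assay; its nearest neighbour is compound 3 and its furthest is compound 2, both gaps beyond the scatter.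

Compound 4 `O=C(/C=C/c1ccc(Oc2ncnc3ccc(Cl)cc23)cc1)/C=C/c1ccc(Cl)c(Cl)c1` is not yet measured. It differs from compound 1 in one place: 3,4-dichlorophenyl in place of 2,6-dichlorophenyl on a double-bonded chain carbon bound to a double-bonded chain carbon.

For the measured compounds named here, only one measured step comes close to this change. In this assay the step of an 8.3-fold higher number from compound 2 to compound 3 (0.92 log units; beyond the scatter) also ends with a 3,4-dichlorophenyl on the double-bonded chain carbon, but it starts from a 2-chloro-5-nitrophenyl, and its shared core carries the quinazolinyl ether on a different aryl than compound 1 and compound 4 do, so it bears on the present step only loosely. Going by the values given here, no step from a 2,6-dichlorophenyl is measured. Given that the 3,4-dichlorophenyl analogue compound 3 holds the highest number seen, a modest step upward is expected for compound 4 in this assay, roughly a 1.5-fold higher number from compound 1 to compound 4 (0.17 log units; within the scatter), with wide uncertainty.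

The estimate for compound 4 in this assay is 10000 nM, expected to fall between 3500 nM and 28000 nM.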

Compound 4, half-maximal inhibitory concentration: 16900 nM
Estimate against measurement, compound 4: 1.7-fold (0.23 log units) below; the measured number falls inside the stated range.
By their numbers in this assay, from the lowest: compound 2; then compound 1; then compounds 3 and 4 (each within the scatter of the next).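

In this assay, for the compounds shown here, the step of a 2.5-fold higher number from compound 1 to compound 4 (0.40 log units; beyond the scatter) is the first measured change away from a 2,6-dichlorophenyl on a double-bonded chain carbon bound to a double-bonded chain carbon. The groups leaving and entering have the same atom counts, so the arrangement of the two chlorines alone is enough to move the number beyond the scatter on this core. Compound 3 at 16200 nM and compound 4 at 16900 nM lie within the scatter of each other, so for the 3,4-dichlorophenyl group the two cores give no separable numbers, and nothing available explains either observation.

Still open, as far as these compounds go, is whether the 2-chloro-5-nitrophenyl group, which gives compound 2 1960 nM on the other core, keeps its lower number on the core of compound 1, and whether 2,6-dichlorophenyl ranks above 3,4-dichlorophenyl on the core of compound 3 as well. Also open is how an unsubstituted phenyl, a 4-aminophenyl or a 4-carboxyphenyl would read at this same place, since the compounds shown carry only chlorine and nitro substituents there.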